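Chloro to cyano on the sulfonyl phenyl ring

The source may report more compounds than this note shows. Statements on the series, on what has been measured and on what is new or still open speak of the compounds shown alone.

Within the data shown here, compound 2 `CC1CCN(c2c(S(=O)(=O)c3ccc(Cl)cc3)cnc3cc(F)ccc23)CC1` stands highest of the two numbers so far in an assay on isolated protein for displacement of a labelled ligand from metabotropic glutamate receptor 5 (Homo sapiens), with a stated time of 60 min, tested at 1 uM (on this read-out lower numbers stand for less inhibition and higher numbers for more inhibition at the one concentration tested (going by the name of the read-out)), at 90%, with compound 1 the nearest and within the scatter. Compound 1 `COc1ccc(S(=O)(=O)c2cnc3cc(F)ccc3c2N2CCC(C)CC2)cc1OC` gives 83% in this assay. Among the measured compounds shown here, the only measured step, a number 7 percentage points higher from compound 1 to compound 2 (within the scatter), puts 4-chlorophenyl in place of 3,4-dimethoxyphenyl on the sulfonyl sulfur; it rearranged the whole substitution of that ring without moving the number beyond the scatter.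

Compound 3 `CC1CCN(c2c(S(=O)(=O)c3ccc(C#N)cc3)cnc3cc(F)ccc23)CC1` has not been measured in this assay. It differs from compound 2 by cyano in place of chloro on an aromatic carbon. For the measured compounds named here, no measured step alters a single substituent on this ring, so the step from compound 1 to compound 2 is the nearest guide, and it was small. The step of a number 5 percentage points lower from compound 2 to compound 3 (within the scatter) is therefore expected to stay within the scatter. Compound 3 is estimated at 85% in this assay, with a range from 65% to 97%.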

Compound 3, a percentage reported as inhibition, at one concentration (the size of the read-out at that concentration, not a potency): 83%
Compound 3: the middle estimate sits 2 percentage points above what was measured; the range from low to high includes it.
By their numbers in this assay, from the lowest: compounds 1, 3 and 2 (each within the scatter of the next).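

Cyano in place of chloro gives a number 7 percentage points lower from compound 2 to compound 3 (within the scatter) in this assay, the first reading of a single substituent changed on the sulfonyl phenyl ring. At this position, a chloro and a cyano group cannot be told apart in this read-out, although cyano brings one hydrogen-bond acceptor and one more heavy atom. 4-Cyanophenyl in place of 3,4-dimethoxyphenyl gives no change at the digits printed from compound 1 to compound 3 (within the scatter), so all three sulfonyl aryl groups shown remain within the scatter of one another. The data give no measured basis for explaining why the numbers stay level.

As far as these compounds go, it remains open whether an amine, a carboxylic acid or a longer alkyl chain at this position would shift the number beyond the scatter. Readings at one concentration also leave open whether compounds with such similar numbers differ in potency.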